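Trimethoxybenzoate isomers on a cinnamate scaffold: estimating compound 4

The source may report more compounds than this note shows. Statements on the series, on what has been measured and on what is new or still open speak of the compounds shown alone.

Measured in a functional assay on Jurkat E6.1 cells (Homo sapiens) for cytotoxicity, read by MTT assay, with a stated time of 24 h; on this read-out higher numbers stand for weaker inhibition and lower numbers for stronger inhibition:
compound 1 `COC(=O)/C(=C\c1ccc(OC(=O)c2cccc(OC)c2)cc1)Sc1ccnc2cc(Cl)ccc12` gives 33300 nM
compound 2 `COC(=O)/C(=C\c1ccc(OC(=O)c2ccc(OC)cc2OC)cc1)Sc1ccnc2cc(Cl)ccc12` gives 10200 nM
compound 3 `COC(=O)/C(=C\c1ccc(OC(=O)c2cc(OC)c(OC)cc2OC)cc1)Sc1ccnc2cc(Cl)ccc12` gives 9650 nM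

Compound 3 gives the lowest of the three numbers in this assay. Its nearest neighbour is compound 2, and the two are within the scatter of each other: a 1.1-fold lower number from compound 2 to compound 3 (0.02 log units; within the scatter). Compound 1 is furthest away, as the step of a 3.5-fold lower number from compound 1 to compound 3 (0.54 log units; beyond the scatter) shows.

The new compound, compound 4 `COC(=O)/C(=C\c1ccc(OC(=O)c2cc(OC)c(OC)c(OC)c2)cc1)Sc1ccnc2cc(Cl)ccc12`, is made from compound 3 by a single change: 3,4,5-trimethoxyphenyl in place of 2,4,5-trimethoxyphenyl on a carbonyl carbon. The two compounds share every atom; only the way the methoxy groups are joined to the ester-bound ring differs.

Two measured steps change the methoxy pattern of that same ring. The step of a 3.3-fold lower number from compound 1 to compound 2 (0.51 log units; beyond the scatter) and the step of a 3.5-fold lower number from compound 1 to compound 3 (0.54 log units; beyond the scatter) both lowered the number by a modest amount, while adding a further methoxy, in the step of a 1.1-fold lower number from compound 2 to compound 3 (0.02 log units; within the scatter), changed nothing beyond the scatter. None of these steps moves a methoxy group from one place to another while keeping the count, so the data give no direct guide for compound 4. The expectation is therefore a step from compound 3 to compound 4 of about a 1.2-fold higher number from compound 3 to compound 4 (0.09 log units; within the scatter), that is, none beyond the scatter. Compound 4 is estimated at 12000 nM, with a range from 5000 nM to 30000 nM.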

Compound 4, half-maximal inhibitory concentration: 4570 nM
Compound 4: the middle estimate sits 2.6-fold (0.42 log units) above what was measured; measured number outside the range, below it.
By their numbers in this assay, from the lowest: compound 4; then compounds 3 and 2 (each within the scatter of the next); then compound 1.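

Compounds 3 and 4 share the same atoms, so this pair shows that the arrangement of methoxy groups on the ester-bound ring matters in this assay: 3,4,5-trimethoxyphenyl in place of 2,4,5-trimethoxyphenyl on a carbonyl carbon gives a 2.1-fold lower number from compound 3 to compound 4 (0.32 log units; beyond the scatter). Among these compounds, the earlier compounds could not separate arrangement from number, and their one step that only added a methoxy group gave a 1.1-fold lower number from compound 2 to compound 3 (0.02 log units; within the scatter). The new ring pattern also gives a 2.2-fold lower number from compound 2 to compound 4 (0.35 log units; beyond the scatter) and a 7.3-fold lower number from compound 1 to compound 4 (0.86 log units; beyond the scatter), which places compound 4 as the most potent of the four in this cell assay, though no supporting measurement bears on what lies behind these differences.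

The compounds shown leave open whether the same arrangement would keep its advantage with ethoxy or hydroxy groups in place of the methoxy groups, or with an amine on the ring. They also leave open whether the lower number of compound 4 would carry over to any cell type other than the one tested here, as all four values come from a single assay.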